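This account rests on a few compounds, and the source may have more. Where it says the series, first, only, none or still open, it means among the compounds named here.

Three compounds of the shared core have been run in an ADME assay on Huh-7 cells (Homo sapiens) for cytotoxicity, read by MTT assay, with a stated time of 72 h; on this read-out higher numbers stand for lower toxicity in this test and lower numbers for higher toxicity in this test. Compound 1 `CCOC(=O)c1sc2nc(-c3cccs3)cc(C(F)(F)F)c2c1N` returns only a limit in this assay, > 20000 nM. Compound 2 `Nc1c(C(=O)NCc2cccs2)oc2nc(-c3ccccc3)cc(C(F)(F)F)c12` likewise returns only a limit in this assay, > 20000 nM. Compound 3 `CCN(CC)C(=O)c1sc2nc(-c3ccccc3)cc(C(F)(F)F)c2c1N` also gives a limit in this assay, > 100000 nM. Going by the values given here, every value is a limit, so no step between measured compounds is resolved. Compound 3 stands at the limit of > 100000 nM in this assay, at which 1 of the 3 values shown sits. Compound 1 and compound 2 both stand at the limit of > 20000 nM in this assay, at which 2 of the 3 values shown sit. Compound 4 `Nc1c(C(=O)N2CCc3sccc3C2)sc2nc(-c3ccccc3)cc(C(F)(F)F)c12` has not yet been measured; it differs from compound 3 by a group of 9 heavy atoms (7 carbon, 1 nitrogen, 1 sulfur; one five-membered aromatic ring with 1 hetero atom, one six-membered non-aromatic ring with 1 hetero atom) in place of a group of 5 heavy atoms (4 carbon, 1 nitrogen; no ring), on a carbonyl carbon. Among the compounds with values here, with every measured value at a limit and no measured step to draw on, the expected step in this assay is none beyond the scatter, namely an at least 1.6-fold lower number from compound 3 to compound 4 (0.22 log units; that floor lies within the scatter). Compound 4 is therefore estimated at 60000 nM in this assay, within 15000 nM to 150000 nM, and most probably reported once more as a limit rather than as a number.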

Compound 4, half-maximal cytotoxic concentration: > 20000 nM
Compound 4: only a limit was reported; the forecaster's own chance of this, stated with the estimate: 70%; the middle value does not contradict the limit.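

Compound 3 and compound 4 both return only limits in this assay, and the step between them cannot be read. The compounds shown leave open whether the group on the carbonyl carbon affects cytotoxicity, as none of the four has a half-maximal cytotoxic concentration given as an actual number.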